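Carbamate swap on the piperidine: tert-butyl to benzyl

A few compounds are considered here, and "the series" means these few. Any claim that something is new, unique, unknown or untested is made for them only; others in the source may bear on it.

Two compounds of this series have numbers in a functional assay on CHO-K1 cells for agonist activity at Glucose-dependent insulinotropic receptor (Homo sapiens), read by cAMP accumulation and immunoassay, with a stated time of 1 h; a higher number here means that more compound is needed for the effect, a lower number that less compound is needed. Compound 1, `Cc1c(Oc2cccc(/C=C3\SC(=O)NC3=O)c2)ncnc1OC1CCN(C(=O)OCc2ccccc2)CC1`, gives 106 nM in this assay. Compound 2, `CC(C)(C)OC(=O)N1CCC(Oc2cc(Oc3cccc(/C=C4\SC(=O)NC4=O)c3)ncn2)CC1`, gives 125 nM in this assay. Compound 2 holds the higher of the two numbers, but its nearest neighbour compound 1 sits within the scatter of it, so the two values are not distinguished by this assay.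

The next compound, compound 3, `O=C1NC(=O)/C(=C/c2cccc(Oc3cc(OC4CCN(C(=O)OCc5ccccc5)CC4)ncn3)c2)S1`, is not yet measured. It is obtained from compound 2 by the change (benzyl in place of tert-butyl on an oxygen next to a carbonyl group), benzyl in place of tert-butyl on an oxygen next to a carbonyl group. Among the measured compounds shown here, no measured pair shows this step alone, so its size is not known from data in hand. Compound 3 is expected to land close to compound 2, with the step of a 1.3-fold lower number from compound 2 to compound 3 (0.10 log units; within the scatter) amounting to no more than the scatter in either direction. The estimate for compound 3 in this assay is therefore 100 nM, with a range from 45 nM to 220 nM.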

Compound 3, half-maximal effective concentration: 153 nM
Compound 3: the middle estimate sits 1.5-fold (0.18 log units) below what was measured; measured number inside the range.
By their numbers in this assay, from the lowest: compounds 1, 2 and 3 (each within the scatter of the next).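

In this assay the carbamate oxygen takes benzyl in place of tert-butyl with a 1.2-fold higher number from compound 2 to compound 3 (0.09 log units; within the scatter) and so accepts one six-membered aromatic ring of carbon only without a step beyond the scatter. The second step, hydrogen in place of methyl on an aromatic carbon, reads as a 1.4-fold higher number from compound 1 to compound 3 (0.16 log units; within the scatter) and also stays within the scatter, so the methyl group is not separated from hydrogen in this benzyl carbamate. Nothing in hand gives a reason for either step.

The compounds shown carry only two carbamate substituents, both without a heteroatom beyond the carbamate itself, so it stays open whether a longer chain such as phenethyl, or a benzyl bearing a carboxylic acid or an amine, would also remain within the scatter at this oxygen. Also open, going by these compounds, are whether an amide or a urea can replace the carbamate, and whether a group such as chlorine or methoxy on that aromatic carbon would give a step beyond the scatter.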